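The compounds below may be only part of what the source reports. "The series", "measured", "known", "first", "only" and "open" are said of these compounds alone.

Three measured compounds share one core and differ only in the group on one aromatic carbon. Compound 1 `Cc1cc(S(=O)(=O)NC(=O)c2ccc(N3CCN(Cc4ccccc4-c4ccc(Cl)cc4)CC3)cc2)ccc1N[C@H](CCN(C)C)CSc1ccccc1` carries a methyl there. In an assay on isolated protein for displacement of a labelled ligand from Bcl2-associated agonist of cell death (Homo sapiens), read by fluorescence polarization (on this read-out lower numbers stand for stronger inhibition and higher numbers for weaker inhibition), compound 1 gives < 1 nM, which is a limit of the assay rather than a number. Compound 2 `CN(C)CC[C@H](CSc1ccccc1)Nc1ccc(S(=O)(=O)NC(=O)c2ccc(N3CCN(Cc4ccccc4-c4ccc(Cl)cc4)CC3)cc2)cc1OC(F)(F)F` carries trifluoromethoxy; in this assay compound 2 gives < 1 nM, again a limit. Compound 3 `CN(C)CC[C@H](CSc1ccccc1)Nc1ccc(S(=O)(=O)NC(=O)c2ccc(N3CCN(Cc4ccccc4-c4ccc(Cl)cc4)CC3)cc2)cc1C#N` carries cyano; in this assay compound 3 gives < 1 nM, also a limit. Because every shown value sits at that limit (the limit of < 1 nM in this assay, at which 3 of the 3 values shown sit), compound 3 cannot be placed above or below its two partners. The steps a step that the two limits leave unreadable from compound 1 to compound 2, a step that the two limits leave unreadable from compound 1 to compound 3 and a step that the two limits leave unreadable from compound 2 to compound 3 are all unreadable in size for the same reason. Compound 4 `CN(C)CC[C@H](CSc1ccccc1)Nc1ccc(S(=O)(=O)NC(=O)c2ccc(N3CCN(Cc4ccccc4-c4ccc(Cl)cc4)CC3)cc2)cc1C(=O)C(F)(F)F` has not yet been measured; it differs from compound 3 by (trifluoromethyl)carbonyl in place of cyano on an aromatic carbon. Since the three measured values all rest at the limit (the limit of < 1 nM in this assay, at which 3 of the 3 values shown sit), no step beyond the scatter is expected, and compound 4 is estimated at 0.5 nM, within a range from 0.1 nM to 3 nM. The expected step is a step that the limit leaves unreadable from compound 3 to compound 4.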

Compound 4, inhibition constant: < 1 nM
Compound 4 ended at the assay's limit (the forecaster's own chance of this, stated with the estimate: 70%); the middle value does not contradict the limit.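

Compound 4 gives a limit rather than a number, as do compound 1, compound 2 and compound 3, and none of the steps to compound 4 can be read in size: the limit of < 1 nM in this assay, at which 4 of the 4 values shown sit. The compounds shown leave open whether the methyl, trifluoromethoxy, cyano and (trifluoromethyl)carbonyl groups differ at all in this assay.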